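This account rests on a few compounds, and the source may have more. Where it says the series, first, only, none or still open, it means among the compounds named here.

Measured compounds and their numbers in an ADME assay on microsomes from liver (Homo sapiens) for metabolic stability, with a stated time of 0.5 h, tested at 0.5 mg/mL; on this read-out higher numbers stand for a more stable compound and lower numbers for a less stable compound:
- compound 1, `CCC(=O)N1CC2(CC(NC(=O)c3cc(-c4ccccc4)no3)C2)C1`, gives 68%
- compound 2, `CC(=O)N1CC(CNC(=O)c2cc(-c3ccccc3)no2)C1`, gives 50%
- compound 3, `CN(C)C(=O)CNC(=O)c1cc(-c2ccc(F)cc2)no1`, gives 84%

Compound 3 holds the highest number of the three in this assay. Its nearest neighbour is compound 1, whose number lies lower by a gap beyond the scatter; compound 2 lies further below, also beyond the scatter. Among the measured compounds shown here, no step between two measured compounds differing in one place is available, so the three numbers stand on their own and carry no single-change comparison.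

Compound 4, `CN(C)C(=O)CCNC(=O)c1cc(-c2ccc(F)cc2)no1`, is not yet measured. It differs from compound 3 in one place: (dimethylcarbamoyl)methyl in place of dimethylcarbamoyl on a saturated chain carbon bound to an amide-type nitrogen. The change adds one saturated chain carbon and leaves the count of donors and acceptors as it stands.

For the measured compounds named here, with no matching step among the measured compounds, the expected shift in this assay is small: the step of a number 8 percentage points lower from compound 3 to compound 4 (within the scatter) is estimated to fall within or only just beyond the scatter, leaning downward. Compound 4 is therefore expected to give 76% in this assay, with a range from 58% to 90%.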

Compound 4, percent of the compound remaining: 87%
Compound 4: the middle estimate sits 11 percentage points below what was measured; measured number inside the range.
By their numbers in this assay, from the lowest: compound 2; then compound 1; then compounds 3 and 4 (each within the scatter of the next).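

In this assay the change from (dimethylcarbamoyl)methyl to 2-(dimethylcarbamoyl)ethyl gives a number 3 percentage points higher from compound 3 to compound 4 (within the scatter) and is the only single-change comparison shown in this series. Among the compounds shown here, compound 3 and compound 4 therefore cannot be told apart on this read-out, which shows that, for this pair, one added saturated chain carbon at the position on a saturated chain carbon bound to an amide-type nitrogen leaves the percent remaining unchanged within the usual scatter, something the three separate numbers of the earlier compounds could not show. No supporting measurement is available to explain why the two compounds read alike.

On these data alone, whether this tolerance extends further remains open: a longer chain, such as a 3-(dimethylcarbamoyl)propyl group, or a chain ending in a carboxylic acid or an amine instead of the dimethylcarbamoyl group, could give a different picture in this assay. For the compounds shown here, compound 1 and compound 2 differ from this pair in more than one place, so the single step gives no indication of how the same chain extension would read on their cores.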